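From pyridin-3-yl to 4-chlorophenyl on the shared core

The compounds below may be only part of what the source reports. "The series", "measured", "known", "first", "only" and "open" are said of these compounds alone.

Compound 1 `O=S1(=O)C=C(Sc2nnc(-c3cccnc3)o2)c2ccccc21` was tested in an ADME assay on HepG2 cells (Homo sapiens) for cytotoxicity, read by fluorescence and resazurin assay, with a stated time of 24 h (a higher number here means that more compound is tolerated, a lower number that less compound is tolerated), and gives 14000 nM; this is the lowest of the three numbers measured, with compound 2 nearest and compound 3 furthest. Compound 2 `COc1ccccc1-c1nnc(SC2=CS(=O)(=O)c3ccccc32)o1` gives 16000 nM and compound 3 `Cc1ccc(-c2nnc(SC3=CS(=O)(=O)c4ccccc43)o2)cc1` gives 31000 nM. The step of a 1.1-fold higher number from compound 1 to compound 2 (0.06 log units; within the scatter) lies within the scatter, while the step of a 2.2-fold higher number from compound 1 to compound 3 (0.35 log units; beyond the scatter) is modest. Compound 4 `O=S1(=O)C=C(Sc2nnc(-c3ccc(Cl)cc3)o2)c2ccccc21` differs from compound 1 in one place: 4-chlorophenyl in place of pyridin-3-yl on an aromatic carbon. Both measured steps from compound 1 replace pyridin-3-yl with a six-membered aromatic ring of carbon only, as this change does, so a small rise in this assay is expected, a 1.6-fold higher number from compound 1 to compound 4 (0.20 log units; within the scatter). For compound 4 the estimate is 22000 nM, with a range from 9000 nM to 50000 nM.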

Compound 4, half-maximal cytotoxic concentration: 22000 nM
The estimate for compound 4 equals the measured number at the digits printed; measured number inside the range.
By their numbers in this assay, from the lowest: compounds 1, 2, 4 and 3 (each within the scatter of the next, the first and the last beyond it).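

In this assay, 4-chlorophenyl is a third ring of carbon only at this position, and all of its steps lie within the scatter (a 1.6-fold higher number from compound 1 to compound 4 (0.20 log units; within the scatter)), (a 1.4-fold higher number from compound 2 to compound 4 (0.14 log units; within the scatter)) and (a 1.4-fold lower number from compound 3 to compound 4 (0.15 log units; within the scatter)). Chloro in place of methyl on this ring therefore cannot be told apart here, and compound 4 adds no new step beyond the scatter. No measurement given accounts for these numbers. Going by these compounds, whether an amine or a carboxylic acid on this ring would move the number beyond the scatter stays open.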